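This account rests on a few compounds, and the source may have more. Where it says the series, first, only, none or still open, it means among the compounds named here.

Measured so far:
- compound 1, `NC[C@@H]1CCCc2cc(S(=O)(=O)c3cccc(F)c3)ccc21`: 0.0794 nM
- compound 2, `O=C1CN=C(NC[C@@H]2CCCc3cc(S(=O)(=O)c4cccc(F)c4)ccc32)N1`: 0.1 nM
- compound 3, `O=C1CN(C[C@@H]2CCCc3cc(S(=O)(=O)c4cccc(F)c4)ccc32)CCN1`: 6.31 nM

All three were tested in an assay on isolated protein for displacement of a labelled ligand from 5-hydroxytryptamine receptor 6 (Homo sapiens); a lower number here means a stronger inhibitor, a higher number a weaker inhibitor. Compound 3 gives the highest number of the three: a 63-fold higher number from compound 2 to compound 3 (1.80 log units; beyond the scatter) and a 79-fold higher number from compound 1 to compound 3 (1.90 log units; beyond the scatter), both beyond the scatter, so compound 3 is the weakest binder of this set. Compound 4, `N=C(N)NC(=O)C[C@@H]1CCCc2cc(S(=O)(=O)c3cccc(F)c3)ccc21`, keeps the shared core and differs from compound 3 in one place: a group of 6 heavy atoms (2 carbon, 3 nitrogen, 1 oxygen; no ring) in place of a group of 7 heavy atoms (4 carbon, 2 nitrogen, 1 oxygen; one six-membered non-aromatic ring with 2 hetero atoms), on a saturated chain carbon bound to a saturated ring carbon. Among the compounds with values here, no measured step reproduces this exact exchange. Within the data shown here, the closest guide is compound 2, whose group on the same chain carbon resembles the one entering in compound 4 in the kinds of atoms it holds, and compound 2 sits close to compound 1, as a 1.3-fold higher number from compound 1 to compound 2 (0.10 log units; within the scatter) shows; the large loss appeared only with the six-membered non-aromatic ring of compound 3. The group in compound 4 carries no ring and no amine of the kind in compound 1, so the outcome is uncertain. Still, removing the ring that went with the loss, and bringing in a group akin to that of compound 2, makes a lower number than compound 3 the more likely direction. The expected step is a 6.3-fold lower number from compound 3 to compound 4 (0.80 log units; beyond the scatter), with wide uncertainty. Compound 4 is therefore estimated at 1 nM, in a range from 0.1 nM to 10 nM.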

Compound 4, inhibition constant: 0.631 nM
For compound 4 the middle estimate is 1.6-fold (0.20 log units) above the measured one; the measured number falls inside the stated range.
By their numbers in this assay, from the lowest: compounds 1 and 2 (each within the scatter of the next); then compound 4; then compound 3.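

In this assay, swapping the 3-oxopiperazin-1-yl for a group with no ring, on the same saturated chain carbon bound to a saturated ring carbon, gives a 10-fold lower number from compound 3 to compound 4 (1.00 log units; beyond the scatter). The large loss seen earlier is therefore not shared by every sizeable group at this place, and much of it is undone by this ringless group. The recovery is only partial, however, with a 6.3-fold higher number from compound 2 to compound 4 (0.80 log units; beyond the scatter) and a 7.9-fold higher number from compound 1 to compound 4 (0.90 log units; beyond the scatter), so a group holding nitrogen and oxygen atoms much like those in compound 2 does not by itself match that compound, and compound 4 lands in the middle of the series. No measurement available here explains any of these differences.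

These groups differ from one another in several features at once, so the compounds shown cannot separate the effect of removing the ring from that of the other changes. Going by these compounds, it also remains open where a carboxylic acid, a plain primary amide or a longer chain at this place would fall relative to compound 1 and compound 3.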